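A few compounds are considered here, and "the series" means these few. Any claim that something is new, unique, unknown or untested is made for them only; others in the source may bear on it.

Measured in a functional assay on MDA-MB-231 cells (Homo sapiens) for cytotoxicity, read by sulforhodamine B assay; on this read-out higher numbers stand for weaker inhibition of growth and lower numbers for stronger inhibition of growth:
- Compound 1 `COC1=C(Br)[C@H](O)[C@@]2(C=C1Br)CC(C(=O)NCCCCCNC(=O)C1=NO[C@]3(C=C(Br)C(=O)[C@@H](Br)[C@@H]3O)C1)=NO2`: 5400 nM
- Compound 2 `COC1=C(Br)[C@H](O)[C@@]2(C=C1Br)CC(C(=O)NCCCCCNC(=O)C1=NO[C@]3(C=C(Br)C(=O)[C@@H]4O[C@@H]43)C1)=NO2`: 5800 nM
- Compound 3 `COC1=C(Br)[C@H](O)[C@@]2(C=C1Br)CC(C(=O)NCCCCCNC(=O)C1=NO[C@]3(C=C(Br)C(OC)(OC)[C@@H](Br)[C@@H]3O)C1)=NO2`: 6000 nM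

In this assay, compound 1 at 5400 nM lies within the usual scatter of both other compounds. Compound 2 at 5800 nM and compound 3 at 6000 nM are likewise not separated from it, so the three values form a single level and no order can be read among them.

The next compound to be tested is compound 4 `COC1=C(Br)[C@H](O)[C@@]2(C=C1Br)CC(C(=O)NCCCCCNC(=O)C1=NO[C@]3(C=C(Br)C(=O)[C@H](Br)[C@@H]3O)C1)=NO2`, which is compared here with compound 1. The structural change is this: the two compounds have the same atoms and bonds and differ only in configuration as drawn: 1 of 5 stereo elements differ; a stereocentre at a saturated ring carbon is drawn S in compound 1 and R in compound 4. No atoms or bonds leave or enter.

Among the compounds with values here, the data contain no measured step between compounds that differ in one place, and so none shows what a change of configuration does. Within the data shown here, the only guide is the common level set by compound 1 at 5400 nM and its two companions. A change beyond the scatter is therefore not expected, and no direction can be favoured.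

The expected result is a 1.0-fold higher number from compound 1 to compound 4 (0.02 log units; within the scatter), which would stay within the scatter. The estimate for compound 4 is 5600 nM, with an expected range from 3300 nM to 9500 nM.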

Compound 4, concentration for total growth inhibition: 4900 nM
Compound 4: the middle estimate sits 1.1-fold (0.06 log units) above what was measured; the range from low to high includes it.
By their numbers in this assay, from the lowest: compounds 4, 1, 2 and 3 (each within the scatter of the next).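

Within the data shown here, this pair supplies the first measured step that differs in one place, which the earlier compounds could not offer. In this assay, redrawing the stereocentre at a saturated ring carbon from S to R gives a 1.1-fold lower number from compound 1 to compound 4 (0.04 log units; within the scatter), so at this position the change of configuration is not separated from the usual variation between repeated measurements. The step can be read as one of configuration alone because nothing else separates the pair: the fact that compounds 1 and 4 differ only in the configuration as drawn.

Going by these compounds, one inversion at one stereocentre in one cell line says nothing about the remaining stereo elements, which compound 1 and compound 4 share, so it remains open whether changing any of those would also leave the read-out at the same level. It also remains open whether a different group on that saturated ring carbon, such as an amine, or a longer chain in the link between the two amide groups, would move the value in this assay beyond the scatter, as no compound shown carries either.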